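This account rests on a few compounds, and the source may have more. Where it says the series, first, only, none or still open, it means among the compounds named here.

Measured so far in a functional assay on HCT-116 cells (Homo sapiens) for antiproliferative activity, read by MTT assay, with a stated time of 72 h; a higher number here means a weaker inhibitor, a lower number a stronger inhibitor:
- compound 1 `COc1ccc(/C=C2/CN(C)/C(=N/c3ccc(C(C)(C)C)cc3)S2)cc1`: 25900 nM
- compound 2 `COc1ccc(/C=C2/CN(C)/C(=N/c3ccc(C(F)(F)F)cc3)S2)cc1`: 34300 nM

These two compounds share a core and differ only in one group on an aromatic carbon. In this assay compound 2 gives 34300 nM, a value that lies within the scatter of compound 1, so the numbers do not separate them.

The next compound, compound 3 `COc1ccc(/C=C2/CN(C)/C(=N/c3ccc(F)cc3)S2)cc1`, keeps the core of compound 2 and carries fluoro in place of trifluoromethyl on an aromatic carbon.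

Among the compounds with values here, only one measured step bears on this change. Trifluoromethyl in place of tert-butyl on an aromatic carbon gave a 1.3-fold higher number from compound 1 to compound 2 (0.12 log units; within the scatter), and that step is within the scatter. A single step sets no trend, and fluoro itself has not yet been measured in this series. No step beyond the scatter is therefore expected in this assay, and neither direction is favoured.

The estimate amounts to an expected 1.1-fold lower number from compound 2 to compound 3 (0.06 log units; within the scatter). For compound 3 the expected value is 30000 nM, with an estimated range of 13000 nM to 70000 nM.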

Compound 3, half-maximal inhibitory concentration: 10000 nM
Compound 3: middle estimate off by 3.0-fold (0.48 log units), on the high side; the measured number lies below the stated range.
By their numbers in this assay, from the lowest: compound 3; then compounds 1 and 2 (each within the scatter of the next).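

In this assay, within the data shown here, the group on this aromatic carbon, para to a large group, now separates the compounds for the first time: fluoro in place of trifluoromethyl gives a 3.4-fold lower number from compound 2 to compound 3 (0.54 log units; beyond the scatter) and fluoro in place of tert-butyl gives a 2.6-fold lower number from compound 1 to compound 3 (0.41 log units; beyond the scatter), both modest steps. Where the exchange of tert-butyl for trifluoromethyl left the numbers unseparated, both steps to fluoro end lower, which makes compound 3 the strongest of the three in this assay and shows that the position does respond to the group it carries, with trifluoromethyl, of 4 heavy atoms, giving way here to fluoro, of 1 heavy atom. No measurement at hand accounts for this difference.

Going by these compounds, with three groups at this position, it remains open whether the number would fall further with hydrogen in place of fluoro, or how chloro, methoxy or an amine would read on the same carbon. On these data alone, it also remains open whether fluoro would give a step of similar size if the rest of the shared core were changed.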